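Hydroxy to Methoxy and Oral Exposure in Monkeys

A few compounds are considered here, and "the series" means these few. Any claim that something is new, unique, unknown or untested is made for them only; others in the source may bear on it.

In an ADME assay on the whole organism (plasma) for pharmacokinetics, with Rhesus monkey (Macaca mulatta) as the target, read by LC-MS, at a dose of 1 mg/kg by the oral route (on this read-out higher numbers stand for higher exposure at the dose given and lower numbers for lower exposure), compound 1 (`O=C1NC(=O)C(Cc2ccc(OCc3nc4ccc(O)cc4[nH]3)cc2)S1`) gives 85.4 ng.h/mL. Within the data shown here, compound 2 (`COc1ccc2nc(COc3ccc(CC(SC)C(=O)O)cc3)n(C)c2c1`) gives 76.8 ng.h/mL, and the two numbers lie within the usual scatter of each other, so compound 1 stands level with the only other measured compound. Compound 3 (`COc1ccc2nc(COc3ccc(CC4SC(=O)NC4=O)cc3)[nH]c2c1`) keeps the core of compound 1 and carries one change: methyl in place of hydrogen on an oxygen on an aromatic ring, a methyl in place of hydrogen on an oxygen on an aromatic ring, or hydroxy to methoxy. Among the measured compounds shown here, no measured pair differs in one place only, so the data offer no direct guide to this change. A modest upward move, only a little beyond the scatter, is expected, and the estimate is a 2.3-fold higher number from compound 1 to compound 3 (0.37 log units; beyond the scatter). For compound 3 the expected exposure is 200 ng.h/mL, with an estimated range of 50 ng.h/mL to 1000 ng.h/mL.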

Compound 3, area under the concentration-time curve: 2300 ng.h/mL
For compound 3 the middle estimate is 12-fold (1.06 log units) below the measured one; measured number outside the range, above it.
By their numbers in this assay, from the lowest: compounds 2 and 1 (each within the scatter of the next); then compound 3.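

Methyl in place of hydrogen on an oxygen on an aromatic ring gives the first single-place comparison here, and in this assay it produces a 27-fold higher number from compound 1 to compound 3 (1.43 log units; beyond the scatter), a large step. Compound 1 and compound 2, which lie within the scatter of each other, gave no sign that this oxygen could be a place where one added methyl goes with so large a change in oral exposure. No measurement shown bears on why the exposure changed.

Going by these compounds, it remains open whether an ethoxy group or a longer chain on this oxygen, or an amine in place of the hydroxy, would give a similar step. Also open is whether hydroxy to methoxy would act alike on the core of compound 2, which has no hydroxy partner among the compounds shown.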